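A few compounds are considered here, and "the series" means these few. Any claim that something is new, unique, unknown or untested is made for them only; others in the source may bear on it.

Measured so far:
compound 1 `CNC1(C)CN(c2c(F)cc3c(=O)c(C(=O)O)cn(C4CC4)c3c2F)C1` — 0.5 ug/mL
compound 2 `CC1(N)CN(c2nc3c(cc2F)c(=O)c(C(=O)O)cn3C2CC2)C1` — 13.9 ug/mL
compound 3 `CNC1(C)CN(c2cc3c(cc2F)c(=O)c(C(=O)O)cn3C2CC2)C1` — 0.7 ug/mL

In a physicochemical assay for solubility, at pH 7.4 (a higher number here means a more soluble compound, a lower number a less soluble compound), compound 1 stands lowest of the three, with compound 3 nearest and compound 2 furthest. For the measured compounds named here, the one single-point step among them, a 1.4-fold higher number from compound 1 to compound 3 (0.15 log units; within the scatter), concerns a change elsewhere on the core. Compound 4 `C[C@H]1[C@H](N)CN1c1c(F)cc2c(=O)c(C(=O)O)cn(C3CC3)c2c1F` differs from compound 1 as follows: a group of 6 heavy atoms (4 carbon, 2 nitrogen; one four-membered non-aromatic ring with 1 hetero atom) in place of a group of 7 heavy atoms (5 carbon, 2 nitrogen; one four-membered non-aromatic ring with 1 hetero atom), on an aromatic carbon. Going by the values given here, no measured step bears on this change; the gap between compound 1 and compound 2 mixes it with other changes, so it cannot be used as a guide. The expectation for compound 4 is therefore a modest rise, a 3.0-fold higher number from compound 1 to compound 4 (0.48 log units; beyond the scatter), with wide uncertainty. Compound 4 is estimated at 1.5 ug/mL, within 0.5 ug/mL to 5 ug/mL.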

Compound 4, solubility: 23.2 ug/mL
Beside the measured number, compound 4's estimate is 15-fold (1.19 log units) below it; the measured number lies above the stated range.
By their numbers in this assay, from the lowest: compounds 1 and 3 (each within the scatter of the next); then compounds 2 and 4 (each within the scatter of the next).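

Working on the core of compound 1, the group on the aromatic carbon ortho to two fluoro groups is a sensitive place in this assay, with a 46-fold higher number from compound 1 to compound 4 (1.67 log units; beyond the scatter). For the compounds shown here, the hydrogen-for-fluoro change gave only a 1.4-fold higher number from compound 1 to compound 3 (0.15 log units; within the scatter), so this is the first single-place step beyond the scatter. The two groups share the four-membered ring and the same counts of hydrogen-bond donors and acceptors, and no measurement on hand accounts for the step.

Which feature of the exchanged groups carries the step remains unresolved, including the two defined stereocentres. As far as these compounds go, whether a pyrrolidine or piperazine ring at this place behaves similarly also remains open.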